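This account rests on a few compounds, and the source may have more. Where it says the series, first, only, none or still open, it means among the compounds named here.

Measured compounds:
Compound 1 `CCCCNC(=O)C1C(C(=O)O)[C@@H]2CC[C@H]1O2` gives 10000 nM in an ADME assay on SW480 cells (Homo sapiens) for cytotoxicity, read by MTT assay, with a stated time of 72 h; a higher number here means a weaker inhibitor of growth, a lower number a stronger inhibitor of growth.
Compound 2 `Cc1cc(C)c(NC(=O)C2C(C(=O)O)[C@@H]3CC[C@H]2O3)c(C)c1` gives 10000 nM in this assay.
Compound 3 `Cn1ccc2cc(CNC(=O)C3C(C(=O)O)[C@@H]4CC[C@H]3O4)ccc21` gives 10000 nM in this assay.

All three share the same core and differ only in the group carried on the amide nitrogen. In this assay compound 1 stands level with compound 2 and compound 3 at the digits printed; none of the three differs from another beyond the usual scatter, so no order among them can be read.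

Compound 4 `O=C(O)CCCNC(=O)C1C(C(=O)O)[C@@H]2CC[C@H]1O2` has not yet been measured. It differs from compound 1 in one place: carboxy in place of methyl on a saturated chain carbon, three bonds along the chain from an amide-type nitrogen. Since compound 1, compound 2 and compound 3 stay level in this assay despite quite different groups on the amide nitrogen, the step expected for compound 4 in this assay is none beyond the scatter, no change at the digits printed from compound 1 to compound 4 (within the scatter). Compound 4 is therefore estimated at 10000 nM, with a range from 4000 nM to 25000 nM.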

Compound 4, concentration for 50% growth inhibition: 10000 nM
Compound 4: the middle estimate sits on the measured number at the digits printed; low and high end bracket the measured number.
By their numbers in this assay, from the lowest: compounds 1, 2, 3 and 4 (each within the scatter of the next).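

In this assay the step is no change at the digits printed from compound 1 to compound 4 (within the scatter) when carboxy replaces methyl on a saturated chain carbon, three bonds along the chain from an amide-type nitrogen. Among these compounds, this is the first single change that can be read, and it shows that putting a carboxy group at this place on the chain leaves the number where it was. No measurement shown here accounts for this result. Still open, going by these compounds, is whether an amine or a longer chain at this place would move the number.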